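The source may hold more compounds than are shown below. What is called first, only, known or untested is meant among the compounds shown, and "the series" means these compounds.

Working notes on the series. The shared core of compound 1 `Nc1scc(CN2CCN(c3ccncc3)CC2)c1C(=O)c1ccc(Cl)cc1` carries on a ring nitrogen a pyridin-4-yl group; in a functional assay on CHO cells with adenosine receptor A1 (Homo sapiens) as the target, read by cAMP accumulation and immunoassay, with a stated time of 6 min, tested at 0.01 uM (a higher number here means a weaker effect of the compound at the concentration tested, a lower number a stronger effect), compound 1 gives -4%. Compound 2 `Nc1scc(CN2CCN(c3cc(Cl)ccc3Cl)CC2)c1C(=O)c1ccc(Cl)cc1` carries a 2,5-dichlorophenyl group in that place, and in this assay compound 2 gives 13%. Among the compounds with values here, on the two numbers so far, compound 2 stands highest, with compound 1 the nearest, as the step of a number 17 percentage points higher from compound 1 to compound 2 (beyond the scatter) shows. Compound 3 `Nc1scc(CN2CCN(c3ccc(Cl)c(Cl)c3)CC2)c1C(=O)c1ccc(Cl)cc1` is not yet measured; the change 3,4-dichlorophenyl in place of 2,5-dichlorophenyl on an amine nitrogen in a ring keeps the same atoms and only joins them differently. Within the data shown here, only one measured step exists, the one from compound 1 to compound 2, and it exchanges the whole aryl group on the ring nitrogen rather than moving two chlorines on one phenyl ring, so it bears on the present step only loosely. With nothing in hand that speaks to the position of the chlorines, the expectation for compound 3 in this assay is a step of no change at the digits printed from compound 2 to compound 3 (within the scatter) that does not go beyond the scatter. The estimate for compound 3 is therefore 13%, expected to fall between -2% and 28%.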

Compound 3, a percentage reported as activity, at one concentration (the size of the read-out at that concentration, not a potency): -1.2%
For compound 3 the middle estimate is 14.2 percentage points above the measured one; low and high end bracket the measured number.
By their numbers in this assay, from the lowest: compounds 1 and 3 (each within the scatter of the next); then compound 2.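

In this assay the arrangement of the two chlorines on the phenyl ring matters: with the same atoms on the amine nitrogen in the ring, the data give a number 14.2 percentage points lower from compound 2 to compound 3 (beyond the scatter) and so show a shift that the earlier exchange of the whole aryl group could not isolate. The data also give a number 2.8 percentage points higher from compound 1 to compound 3 (within the scatter) for the exchange of pyridin-4-yl for 3,4-dichlorophenyl, so among these compounds the earlier step away from pyridin-4-yl holds for the 2,5-dichlorophenyl group and does not extend to every dichlorophenyl group. Nothing at hand accounts for the difference between the two chlorine arrangements. The compounds shown leave open how an unsubstituted phenyl group, a phenyl group with a single chlorine, or a phenyl group carrying a methoxy or trifluoromethyl group would read in this place, and so whether the 2,5-dichlorophenyl group stands alone or belongs to a wider trend. As the read-out comes from one concentration and is not a potency, these compounds also leave open whether the gap between the two dichlorophenyl isomers would hold across a full concentration range.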